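Methyl in place of hydrogen on the pyrrole-type ring

The compounds below may be only part of what the source reports. "The series", "measured", "known", "first", "only" and "open" are said of these compounds alone.

Compound 1 `Fc1ccc(Oc2ncnc3[nH]ccc23)c(F)c1`: 710 nM
Compound 2 `Fc1ccccc1Oc1ncnc2[nH]ccc12`: limit, > 32000 nM

Going by the values given here, compound 1 is the only compound with a number in an assay on HEK293-TREx cells for antagonist activity at transient receptor potential cation channel subfamily A member 1 (Homo sapiens), read by fluorescence and calcium flux, with a stated time of 72 h; a lower number here means a stronger inhibitor, a higher number a weaker inhibitor; there compound 1 gives 710 nM. Compound 2 reaches only the assay limit in this assay, recorded as > 32000 nM. Among the compounds with values here, the one measured step, an at least 45-fold higher number from compound 1 to compound 2 (1.65 log units; beyond the scatter), is large, and its size rests on the limit of > 32000 nM in this assay, at which 1 of the 2 values shown sits, rather than on a second number. Compound 3 `Cc1cc2c(Oc3ccc(F)cc3F)ncnc2[nH]1` keeps both fluoro groups of compound 1 and differs from it by methyl in place of hydrogen on an aromatic carbon. The measured step concerns a change on the other ring, so it gives no direct guide to the effect of the methyl on the ring that carries it. Within the data shown here, with no measured step bearing on the change, no shift beyond the scatter is expected. For compound 3 the expected step is a 1.0-fold lower number from compound 1 to compound 3 (0.01 log units; within the scatter), so the estimate for compound 3 is 700 nM, with a range from 200 nM to 3000 nM.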

Compound 3, half-maximal inhibitory concentration: 1200 nM
Beside the measured number, compound 3's estimate is 1.7-fold (0.23 log units) below it, and the stated range covers the measured number.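

The step at this position is a 1.7-fold higher number from compound 1 to compound 3 (0.23 log units; within the scatter), so in this assay a methyl on an aromatic carbon of the five-membered aromatic ring, next to the ring nitrogen, gives no shift that can be told from the scatter. Going by these compounds alone, the earlier compounds showed only a change on the other ring, and this is the first reading at this position, taken between two numbers rather than against an assay limit. No measured property of these compounds bears on this result.

Going by these compounds, whether this position also accepts a larger or charged group stays open, for example an ethyl chain, an amine or a carboxylic acid. A single methyl step also leaves open whether the same holds when the fluoro pattern of compound 3 is changed.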